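This account rests on a few compounds, and the source may have more. Where it says the series, first, only, none or still open, it means among the compounds named here.

For the measured compounds named here, compound 1 `CC(C)C(c1ncco1)c1ccc(-c2ccc3cccc(F)c3c2)[nH]c1=O` stands at the lowest of the two numbers measured so far: in an assay on CHO cells for displacement of a labelled ligand from prostaglandin E2 receptor EP3 subtype (Homo sapiens), read by radioligand binding (a higher number here means a weaker inhibitor, a lower number a stronger inhibitor), compound 1 gives 24 nM, with its only neighbour within the usual scatter. That neighbour, compound 2 `CC(C)C(Cc1nnn[nH]1)c1ccc(-c2ccc3cccc(F)c3c2)[nH]c1=O`, gives 34 nM in this assay. Going by the values given here, the one step that bears on the new compound, a 1.4-fold higher number from compound 1 to compound 2 (0.15 log units; within the scatter), changed the group at the same place and stayed within the scatter. Compound 3 `CC(C)C(/C=C1\CCNC1=O)c1ccc(-c2ccc3cccc(F)c3c2)[nH]c1=O` differs from compound 1 by a group of 7 heavy atoms (5 carbon, 1 nitrogen, 1 oxygen; one five-membered non-aromatic ring with 1 hetero atom) in place of a group of 5 heavy atoms (3 carbon, 1 nitrogen, 1 oxygen; one five-membered aromatic ring with 2 hetero atoms), on a saturated chain carbon bound to an aromatic carbon and a saturated chain carbon. A step of a 1.3-fold higher number from compound 1 to compound 3 (0.10 log units; within the scatter) is therefore expected, nothing beyond the scatter. Compound 3 is expected to give 30 nM, within 10 nM to 90 nM.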

Compound 3, inhibition constant: 2.2 nM
Estimate against measurement, compound 3: 14-fold (1.13 log units) above; the whole stated range lies above it.
By their numbers in this assay, from the lowest: compound 3; then compounds 1 and 2 (each within the scatter of the next).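

Until now, the two groups at this saturated chain carbon, 1,3-oxazol-2-yl and (1H-tetrazol-5-yl)methyl, gave values within the scatter of each other, so the position could have seemed indifferent to the change. The non-aromatic five-membered ring group shows otherwise in this assay (an 11-fold lower number from compound 1 to compound 3 (1.04 log units; beyond the scatter); a 15-fold lower number from compound 2 to compound 3 (1.19 log units; beyond the scatter)), so the group at this place can strongly change the number. Nothing measured here explains this step. Open, on these data alone, is which part of the entering group matters: its ring, its double bonds or its amide hydrogen. An open-chain amide or an amine at this place would help separate these.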